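Ethyl in place of hydrogen on the oxygen of compound 3

The source may report more compounds than this note shows. Statements on the series, on what has been measured and on what is new or still open speak of the compounds shown alone.

Compound 3 `Nc1nc(Nc2ccc(Cl)cc2)cc(-c2cc(Cl)ccc2O)n1` gives 10000 nM in an assay on Sf9 cells for inhibition of 1-acyl-sn-glycerol-3-phosphate acyltransferase beta (Homo sapiens) (on this read-out higher numbers stand for weaker inhibition and lower numbers for stronger inhibition), the highest number of the three measured, set against compound 1 `COc1ccc(Cl)cc1-c1cc(Nc2ccc(Cl)cc2)nc(N)n1` at 54 nM and compound 2 `Nc1nc(Nc2ccc(Cl)cc2)cc(-c2cc(Cl)ccc2Cl)n1` at 20 nM; both steps, a 190-fold higher number from compound 1 to compound 3 (2.27 log units; beyond the scatter) and a 500-fold higher number from compound 2 to compound 3 (2.70 log units; beyond the scatter), lie beyond the scatter. Compound 4 `CCOc1ccc(Cl)cc1-c1cc(Nc2ccc(Cl)cc2)nc(N)n1` differs from compound 3 by ethyl in place of hydrogen on an oxygen on an aromatic ring. The step that bears on this is a 190-fold higher number from compound 1 to compound 3 (2.27 log units; beyond the scatter), the reverse of a methyl capping the same oxygen, which was large. Compound 4 is therefore expected to fall far below compound 3, roughly back to where compound 1 stands, since nothing measured separates ethyl from methyl on that oxygen. Estimate for compound 4: 60 nM (range 15 nM to 250 nM), an expected step of a 170-fold lower number from compound 3 to compound 4 (2.22 log units; beyond the scatter).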

Compound 4, half-maximal inhibitory concentration: 17 nM
Compound 4: middle estimate off by 3.5-fold (0.55 log units), on the high side; the range from low to high includes it.
By their numbers in this assay, from the lowest: compounds 4 and 2 (each within the scatter of the next); then compound 1; then compound 3.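

Capping the oxygen with ethyl undoes the loss seen with the free hydroxy (a 590-fold lower number from compound 3 to compound 4 (2.77 log units; beyond the scatter)), and this position accepts more than methyl on that oxygen. The added carbon still registers, with methoxy going to ethoxy giving a 3.2-fold lower number from compound 1 to compound 4 (0.50 log units; beyond the scatter), while ethoxy and chloro cannot be told apart (a 1.2-fold lower number from compound 2 to compound 4 (0.07 log units; within the scatter)). Nothing available explains these differences.

Going by these compounds, whether a longer chain such as propoxy, or a branched isopropoxy, keeps this level remains open. So does whether an amine on this aromatic carbon reads like hydroxy or like ethoxy.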